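Cyclohexyl replaces isobutyl on the amine nitrogen

This account rests on a few compounds, and the source may have more. Where it says the series, first, only, none or still open, it means among the compounds named here.

Compound 1 `CCCNC(=C\C(=O)/C=C/c1ccc(O)c(OC)c1)/C=C/c1ccc(O)c(OC)c1`: in a functional assay on Caco-2 cells (Homo sapiens), read by fluorescence, tested at 10 uM (a higher number here means a weaker effect of the compound at the concentration tested, a lower number a stronger effect), compound 1 gives 88%.
Compound 2 `CCC(C)NC(=C\C(=O)/C=C/c1ccc(O)c(OC)c1)/C=C/c1ccc(O)c(OC)c1`: in this assay compound 2 gives 66%.
Compound 3 `CC(C)CNC(=C\C(=O)/C=C/c1ccc(O)cc1)/C=C/c1ccc(O)cc1`: in this assay compound 3 gives 82%.

Compound 3 stands second highest of the three numbers. Its nearest neighbour is compound 1, whose value lies within the scatter of compound 3, and the furthest is compound 2, whose value lies beyond the scatter, lower than compound 3.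

Compound 4 `O=C(/C=C(/C=C/c1ccc(O)cc1)NC1CCCCC1)/C=C/c1ccc(O)cc1` differs from compound 3 in a single place: cyclohexyl in place of isobutyl on an amine nitrogen. Within the data shown here, only one measured step bears on this change, a number 22 percentage points lower from compound 1 to compound 2 (beyond the scatter), where a methyl in place of hydrogen on a saturated chain carbon bound to an amine nitrogen brought the number down by a modest amount. The change from isobutyl to cyclohexyl likewise enlarges the group on the amine nitrogen, so a step in the same direction, of a similar or somewhat smaller size, is expected rather than none. The account therefore expects a number 12 percentage points lower from compound 3 to compound 4 (beyond the scatter). For compound 4 the value in this assay is estimated at 70%, with a range from 55% to 88%.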

Compound 4, a percentage reported as activity, at one concentration (the size of the read-out at that concentration, not a potency): 82%
The estimate for compound 4 lay 12 percentage points below the measured number; measured number inside the range.
By their numbers in this assay, from the lowest: compound 2; then compounds 3, 4 and 1 (each within the scatter of the next).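

In this assay, cyclohexyl in place of isobutyl on the amine nitrogen gives no change at the digits printed from compound 3 to compound 4 (within the scatter), so at this position on the core of compound 3, an open branched chain can give way to a six-membered carbon ring with no difference that can be told apart in the read-out. Among these compounds, the only earlier step at this nitrogen, a number 22 percentage points lower from compound 1 to compound 2 (beyond the scatter), was on the core of compound 1 and involved a different change, and its downward shift does not recur here: a larger group on the nitrogen does not by itself lower the number, with compound 2 showing the shift and compound 4 not. Nothing available explains why the two steps differ.

The compounds shown leave open whether cyclohexyl would behave the same way on the core of compound 1, which carries the methoxy groups, and whether the sec-butyl group of compound 2 would lower the number on the core of compound 3. They also leave open what a cyclopropyl, a benzyl or a chain ending in a carboxylic acid would do on the amine nitrogen.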